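Cytotoxicity in the series: from compound 3 to compound 4

This account rests on a few compounds, and the source may have more. Where it says the series, first, only, none or still open, it means among the compounds named here.

Compound 1 `Fc1cccc(F)c1Cn1cccc2nc(-c3c(F)cccc3F)nc1-2` sits at the limit of an ADME assay on MDBK cells (Bos taurus) for cytotoxicity (on this read-out higher numbers stand for lower toxicity in this test and lower numbers for higher toxicity in this test), giving > 100000 nM. Compound 2 `Cc1ccn(Cc2c(F)cccc2F)c2nc(-c3c(F)cccc3F)nc1-2` likewise gives only the limit > 100000 nM. The step that the two limits leave unreadable from compound 1 to compound 2 is therefore not readable. Compound 3 `Cc1ccccc1Cn1ccc2nc(-c3ccccc3)nc-2c1` also gives only the limit > 100000 nM. All three measured values share (the limit of > 100000 nM in this assay, at which 3 of the 3 values shown sit). Compound 4 `Clc1ccc(Cn2ccc3nc(-c4ccccc4)nc-3c2)cc1` is not yet measured. The change is 4-chlorophenyl in place of 2-methylphenyl on a saturated chain carbon bound to an aromatic nitrogen. Among the compounds with values here, no measured step bears on this change; the single measured step is unreadable. Within the data shown here, because every value so far rests on (the limit of > 100000 nM in this assay, at which 3 of the 3 values shown sit), compound 4 is expected to remain at the limit as well, an estimated step that the limit leaves unreadable from compound 3 to compound 4 within the scatter. The estimate for compound 4 in this assay is 150000 nM, with a range from 50000 nM to 400000 nM.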

Compound 4, half-maximal cytotoxic concentration: > 100000 nM
Compound 4: only a limit was reported (the forecaster's own chance of this, stated with the estimate: 85%); the middle value does not contradict the limit.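

In this assay compound 3 and compound 4 each give only a limit, so the step between them cannot be read. The compounds shown leave open whether any change to this series produces a measurable cytotoxic concentration.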